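The source may hold more compounds than are shown below. What is called first, only, known or untested is meant among the compounds shown, and "the series" means these compounds.

Three compounds have been measured so far in a functional assay on Jurkat cells (Homo sapiens) (on this read-out lower numbers stand for stronger inhibition and higher numbers for weaker inhibition), as follows:

compound 1 `C[C@H](NC(=O)C(=O)NCc1ccc(Cl)cc1)C(=O)N[C@@H](CC(=O)O)C(=O)COc1c(F)c(F)cc(F)c1F` gives 8.4 nM
compound 2 `C[C@H](NC(=O)C(=O)Nc1cccnc1N(C)C)C(=O)N[C@@H](CC(=O)O)C(=O)COc1c(F)c(F)cc(F)c1F` gives 27 nM
compound 3 `Cc1ccc(CNC(=O)C(=O)N[C@@H](C)C(=O)N[C@@H](CC(=O)O)C(=O)COc2c(F)c(F)cc(F)c2F)cc1` gives 50 nM

Compound 3 lies within the scatter of compound 2 (a 1.9-fold higher number from compound 2 to compound 3 (0.27 log units; within the scatter)) and clearly apart from compound 1 (a 6.0-fold higher number from compound 1 to compound 3 (0.77 log units; beyond the scatter)). Compound 4 `C[C@H](NC(=O)C(=O)NCc1ccccc1F)C(=O)N[C@@H](CC(=O)O)C(=O)COc1c(F)c(F)cc(F)c1F` differs from compound 3 in one group: 2-fluorophenyl in place of 4-methylphenyl on a saturated chain carbon bound to an amide-type nitrogen.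

The closest evidence is the swap of chloro for methyl on the aromatic ring, which gave a modest step (a 6.0-fold higher number from compound 1 to compound 3 (0.77 log units; beyond the scatter)). A larger replacement of the whole group stayed within the scatter (a 1.9-fold higher number from compound 2 to compound 3 (0.27 log units; within the scatter)). Going by the values given here, no measured step tests a fluoro group, so the direction is uncertain. Compound 1 offers only a slight lean toward a lower number. No step beyond the scatter is therefore expected in this assay and a modest drop is the most that seems likely.

The estimate corresponds to an expected step (a 1.8-fold lower number from compound 3 to compound 4 (0.25 log units; within the scatter)) of this small size. For compound 4 the expected value is 28 nM with an estimated range of 9 nM to 80 nM as its limits.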

Compound 4, half-maximal inhibitory concentration: 207 nM
The estimate for compound 4 lay 7.4-fold (0.87 log units) below the measured number; the whole stated range lies below it.
By their numbers in this assay, from the lowest: compound 1; then compounds 2 and 3 (each within the scatter of the next); then compound 4.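

In this assay, going by these compounds alone, the substituent on the benzyl ring matters more than the earlier compounds suggested: 2-fluorophenyl in place of 4-methylphenyl gives a clear loss (a 4.1-fold higher number from compound 3 to compound 4 (0.62 log units; beyond the scatter)), and in place of 4-chlorophenyl a large one (a 25-fold higher number from compound 1 to compound 4 (1.39 log units; beyond the scatter)). The 2-fluorobenzyl group also sets compound 4 clearly apart from the 2-(dimethylamino)pyridin-3-yl compound (a 7.7-fold higher number from compound 2 to compound 4 (0.88 log units; beyond the scatter)), whereas compound 3 stayed within the scatter of that same compound. No measurement here accounts for these losses.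

This change alters both the substituent and its place on the ring, so the two cannot yet be separated. A 4-fluorobenzyl, 2-chlorobenzyl or unsubstituted benzyl group on the same nitrogen would show which of them matters.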